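The source may report more compounds than this note shows. Statements on the series, on what has been measured and on what is new or still open speak of the compounds shown alone.

Measured so far:
compound 1 `COC(C)CCOCn1cc[n+](C)c1/C=N/O` — in a physicochemical assay for lipophilicity (a higher number here means a more lipophilic compound, a lower number a more polar compound), compound 1 gives -2.22
compound 2 `C[n+]1ccn(CCC#N)c1/C=N/O` — in this assay compound 2 gives -3.3

Compound 2 holds the lower of the two numbers; compound 1 stands higher by a gap beyond the usual scatter. Among the compounds with values here, no two measured compounds differ in only one place, so no single-change step is known.

Compound 3 `C[n+]1ccn(CCOCCF)c1/C=N/O` remains to be measured in this assay. It differs from compound 2 by 2-fluoroethoxy in place of cyano on a saturated chain carbon, two bonds along the chain from an aromatic nitrogen. Within the data shown here, with no measured step to lean on, the direction is read from the two numbers: the change brings the side chain closer in kind to that of compound 1, whose value -2.22 is the higher one. The step is expected to go upward, beyond the scatter but short of the full gap between compound 2 and compound 1. The expected step is a number 0.60 log units higher from compound 2 to compound 3 (beyond the scatter). Compound 3 is estimated at -2.7, with a range from -3.2 to -2.1.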

Compound 3, distribution coefficient: -2.62
The estimate for compound 3 lay 0.08 log units below the measured number, and the stated range covers the measured number.
By their numbers in this assay, from the lowest: compound 2; then compound 3; then compound 1.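

Within the data shown here, at the saturated chain carbon two bonds along the chain from an aromatic nitrogen, the series now has its only single-change step: in this assay, 2-fluoroethoxy in place of cyano gives a number 0.68 log units higher from compound 2 to compound 3 (beyond the scatter), so the number at this position depends on the group carried there by more than the scatter. The leaving cyano and the entering 2-fluoroethoxy each carry 1 hydrogen-bond acceptor and no net charge, so the step arises with those two counts unchanged, while the heavy atoms go from 2 to 4. No measurement at hand bears on why the number moves.

A single step does not separate the contributions of the oxygen, the fluorine and the added chain length within 2-fluoroethoxy. From the compounds shown here alone, how an amine or a carboxylic acid on the same chain carbon would stand in this assay also remains open.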